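Opening the aminocyclopentyl ring in the biphenyl amide series

A few compounds are considered here, and "the series" means these few. Any claim that something is new, unique, unknown or untested is made for them only; others in the source may bear on it.

For the measured compounds named here, compound 2 `NC1(CN(C(=O)[C@@H]2C[C@H]2c2ccccc2)c2ccc(-c3ccccc3)cc2)CCCC1` gives 0.57 nM in a functional assay for agonist activity at G protein-coupled receptor 88 (Homo sapiens), read by HTRF and cAMP accumulation (on this read-out higher numbers stand for an effect only at larger amounts of compound and lower numbers for an effect already at smaller amounts), the lowest of the two numbers measured so far; its nearest neighbour is compound 1 `CC(C)C[C@H](N)CN(C(=O)[C@@H]1C[C@H]1c1ccccc1)c1ccc(-c2ccccc2)cc1`, which in this assay gives 880 nM. Going by the values given here, the only measured step on this position is a 1500-fold lower number from compound 1 to compound 2 (3.19 log units; beyond the scatter), a large move that came with 1-aminocyclopentyl in place of 1-amino-3-methylbutyl. Compound 3 `CC(C)(N)CN(C(=O)[C@@H]1C[C@H]1c1ccccc1)c1ccc(-c2ccccc2)cc1` is unmeasured; it carries 1-amino-1-methylethyl in place of 1-aminocyclopentyl on a saturated chain carbon bound to an amide-type nitrogen. Among the compounds with values here, no step from a ring to an open 1-amino-1-methylethyl group has been measured, so the one step on this position bears on it only loosely: it shows the position is sensitive, not which way this change goes. A moderate rise in the number is expected, since compound 3 neither keeps the ring of compound 2 nor returns to the chain of compound 1, estimated as an 8.8-fold higher number from compound 2 to compound 3 (0.94 log units; beyond the scatter). For compound 3 the expected value in this assay is 5 nM, with a range of 0.6 nM to 40 nM.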

Compound 3, half-maximal effective concentration: 1.4 nM
For compound 3 the middle estimate is 3.6-fold (0.55 log units) above the measured one, within the range that was stated.
By their numbers in this assay, from the lowest: compound 2; then compound 3; then compound 1.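

In this assay, opening the ring gives only a 2.5-fold higher number from compound 2 to compound 3 (0.39 log units; beyond the scatter) as a modest step, so the 1-aminocyclopentyl ring is not needed for a low number on this saturated chain carbon bound to an amide-type nitrogen. Replacing 1-amino-3-methylbutyl with the open 1-amino-1-methylethyl group gives a 630-fold lower number from compound 1 to compound 3 (2.80 log units; beyond the scatter) as a large step, so most of the gap between compound 1 and compound 2 remains without any ring and tracks the 1-amino-3-methylbutyl group, not the ring itself. No data at hand explain either step.

The compounds shown leave open whether 1-aminoethyl or 1-amino-1-methylpropyl would keep a number close to that of compound 3. They also leave open whether 1-aminocyclobutyl or 1-aminocyclohexyl would match compound 2.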